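A few compounds are considered here, and "the series" means these few. Any claim that something is new, unique, unknown or untested is made for them only; others in the source may bear on it.

Measured so far in a functional assay on HEK293 cells for positive allosteric modulation of metabotropic glutamate receptor 5 (Rattus norvegicus), read by fluorescence and calcium flux; on this read-out higher numbers stand for larger maximal responses and lower numbers for smaller maximal responses:
Compound 1 `C[C@@H](NC(=O)c1ccc(C#Cc2cccc(F)c2)cn1)C(C)(C)C`; compound 1 gives 66%.
Compound 2 `CC(C)[C@@H](C)NC(=O)c1ccc(C#Cc2cccc(F)c2)cn1`; compound 2 gives 69.3%.
Compound 3 `C[C@@H](NC(=O)c1ccc(C#Cc2ccccn2)cn1)C(C)(C)C`; compound 3 gives 63%.

Compound 3 stands lowest of the three numbers, but its gaps to compound 1 and to compound 2 both lie within the scatter, so no order among them can be claimed. Compound 4 `CC(C)[C@@H](C)NC(=O)c1ccc(C#Cc2ccccn2)cn1` differs from compound 3 by hydrogen in place of methyl on a saturated chain carbon bound to three saturated chain carbons. The same change has been measured once before, on the other aryl group: a number 3.3 percentage points higher from compound 1 to compound 2 (within the scatter). The exchange of the aryl group itself, a number 3 percentage points lower from compound 1 to compound 3 (within the scatter), was equally small. Neither step bears a change beyond the scatter, so for compound 4 in this assay a step of a number 3 percentage points higher from compound 3 to compound 4 (within the scatter) is expected, within the scatter. Compound 4 is therefore estimated at 66%, within 55% to 77%.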

Compound 4, largest response reached (reported as efficacy), in percent of the reference or control that the assay uses: 58.5%
The estimate for compound 4 lay 7.5 percentage points above the measured number, and the stated range covers the measured number.
By their numbers in this assay, from the lowest: compounds 4, 3, 1 and 2 (each within the scatter of the next, the first and the last beyond it).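

In this assay, hydrogen in place of methyl on a saturated chain carbon bound to three saturated chain carbons has now been read on a second core, a number 4.5 percentage points lower from compound 3 to compound 4 (within the scatter), and the two readings of this change agree: the same change on two cores in this assay, a number 3.3 percentage points higher (within the scatter) from compound 1 to compound 2 and a number 4.5 percentage points lower (within the scatter) from compound 3 to compound 4, 7.8 percentage points apart, within the scatter of two such steps. Pyridin-2-yl in place of 3-fluorophenyl now gives the one step here beyond the scatter, a number 10.8 percentage points lower from compound 2 to compound 4 (beyond the scatter), yet that step does not part from the earlier reading of the same exchange: the same change on two cores in this assay, a number 3 percentage points lower (within the scatter) from compound 1 to compound 3 and a number 10.8 percentage points lower (beyond the scatter) from compound 2 to compound 4, 7.8 percentage points apart, within the scatter of two such steps.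

From the compounds shown here alone, what remains open is how the maximal response would stand with an amine, a carboxylic acid or a longer chain on this saturated chain carbon.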